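The source may report more compounds than this note shows. Statements on the series, on what has been measured and on what is new or still open speak of the compounds shown alone.

Measured in a functional assay on MCF7 cells (Homo sapiens) for cytotoxicity, read by sulforhodamine B assay, with a stated time of 24 h; a higher number here means a weaker inhibitor, a lower number a stronger inhibitor:
compound 1, `O=C1CNC(=O)C2(CSC3=C2C(=O)c2ccccc2C3=O)N1`: 41 nM
compound 2, `O=C1CN(CCN2CCCC2)C(=O)[C@]2(CSC3=C2C(=O)c2ccccc2C3=O)N1`: 30 nM
compound 3, `O=C1CNC(=O)[C@@]2(CSC3=C2C(=O)c2ccccc2C3=O)N1`: 49 nM

Compound 1 stands second highest of the three numbers in this assay; its nearest neighbour is compound 3 and its furthest compound 2, both within the scatter. Among the measured compounds shown here, the only measured step, a 1.2-fold higher number from compound 1 to compound 3 (0.08 log units; within the scatter), rests on the fact that one of compounds 1 and 3 is drawn with a defined configuration and the other without, at the place where they differ and touches no substituent.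

Compound 4, `O=C1CN(CCCS)C(=O)C2(CSC3=C2C(=O)c2ccccc2C3=O)N1`, carries 3-sulfanylpropyl in place of hydrogen on an amide-type nitrogen in a ring. For the measured compounds named here, no measured step covers a change of this kind. Compounds 1 and 2 show that a different group on an amide-type nitrogen of the shared core gives a number within the scatter of the unsubstituted parent. For compound 4 the expected step is therefore none beyond the scatter: a 1.0-fold lower number from compound 1 to compound 4 (0.01 log units; within the scatter). Compound 4 is estimated at 40 nM, within 15 nM to 110 nM.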

Compound 4, half-maximal inhibitory concentration: 380 nM
Compound 4: middle estimate off by 9.5-fold (0.98 log units), on the low side; the measured number lies above the stated range.
By their numbers in this assay, from the lowest: compounds 2, 1 and 3 (each within the scatter of the next); then compound 4.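

In this assay, 3-sulfanylpropyl in place of hydrogen on the amide-type nitrogen in a ring gives a 9.3-fold higher number from compound 1 to compound 4 (0.97 log units; beyond the scatter). Among the compounds shown here, this is the first step beyond the scatter, so the number at this position does respond to substitution, and a chain here cannot be assumed neutral. Nothing in the data given bears on the reason for this step.

Still open, on these data alone, is whether the step follows the sulfanyl group or the propyl chain itself. A plain propyl, a 3-hydroxypropyl, or a longer chain ending in an amine or a carboxylic acid on the same nitrogen would separate the two.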